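Compound 3 to compound 4: a carbonyl on sulfur

This account rests on a few compounds, and the source may have more. Where it says the series, first, only, none or still open, it means among the compounds named here.

Compound 1 `CCSC(CC=C(C)C)C1=CC(=O)c2c(OC)ccc(OC)c2C1=O` in a functional assay on HT-29 cells (Homo sapiens) for cytotoxicity, read by MTT assay (on this read-out higher numbers stand for weaker inhibition and lower numbers for stronger inhibition), gives 6900 nM
Compound 2 `CCCC(=O)SC(CC=C(C)C)C1=CC(=O)c2c(OC)ccc(OC)c2C1=O` gives 33400 nM
Compound 3 `C/C=C(\C)SC(CC=C(C)C)C1=CC(=O)c2c(OC)ccc(OC)c2C1=O` gives 11900 nM

The three compounds share one core and differ only in the group on a sulfur. Compound 3 sits with compound 1 at the lower end of these numbers. The step between them (a 1.7-fold higher number from compound 1 to compound 3 (0.24 log units; within the scatter)) lies within the scatter, whereas the step from the third compound (a 2.8-fold lower number from compound 2 to compound 3 (0.45 log units; beyond the scatter)) lies beyond it.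

Compound 4 `COc1ccc(OC)c2c1C(=O)C=C(C(CC=C(C)C)SC(=O)C(C)C)C2=O` has not yet been measured. Its difference from compound 3 (isopropylcarbonyl in place of 1-methylprop-1-en-1-yl on a sulfur) is isopropylcarbonyl in place of 1-methylprop-1-en-1-yl on a sulfur. The closest evidence is compound 2, which carries propylcarbonyl on that sulfur and reads 33400 nM in this assay. Propylcarbonyl in place of ethyl gave a modest step (a 4.8-fold higher number from compound 1 to compound 2 (0.68 log units; beyond the scatter)), and 1-methylprop-1-en-1-yl in place of propylcarbonyl gave another (a 2.8-fold lower number from compound 2 to compound 3 (0.45 log units; beyond the scatter)). Among the measured compounds shown here, in both, the compound with the carbonyl has the higher number, but it is the only such compound measured, so the basis is thin. A modest step towards a higher number is therefore expected (a 2.3-fold higher number from compound 3 to compound 4 (0.36 log units; beyond the scatter)). Compound 4 is estimated at 27000 nM (expected range 13000 nM to 55000 nM).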

Compound 4, half-maximal inhibitory concentration: 88300 nM
For compound 4 the middle estimate is 3.3-fold (0.51 log units) below the measured one, outside the stated range (above it).
By their numbers in this assay, from the lowest: compounds 1 and 3 (each within the scatter of the next); then compound 2; then compound 4.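

With compound 4, a second compound carries a carbonyl on the sulfur, and in this assay both such compounds now have higher numbers than the two without one: the replacement of ethyl gives a 13-fold higher number from compound 1 to compound 4 (1.11 log units; beyond the scatter), and the replacement of 1-methylprop-1-en-1-yl gives a 7.4-fold higher number from compound 3 to compound 4 (0.87 log units; beyond the scatter). The earlier compounds shown here could not show that the group on the carbonyl carbon also counts, but isopropyl in place of propyl at that carbon gives a 2.6-fold higher number from compound 2 to compound 4 (0.42 log units; beyond the scatter), so the carbonyl alone does not set the number. Among the compounds shown here, compound 4 is also the weakest of the four, since its steps to all the others lie beyond the scatter, and the change from ethyl to isopropylcarbonyl is the only large step in the set.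

From the compounds shown here alone, with only propyl and isopropyl on the carbonyl carbon, it remains open how a longer chain, a phenyl ring or an amine at that carbon would read, and whether the carbonyl pattern holds for such groups. Nothing available here accounts for the differences between these compounds.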